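A few compounds are considered here, and "the series" means these few. Any claim that something is new, unique, unknown or untested is made for them only; others in the source may bear on it.

Measured so far in a functional assay on HEK293 cells for agonist activity at G-protein coupled receptor 39 (Homo sapiens), read by scintillation proximity assay and inositol phosphate accumulation, with a stated time of 75 min; a higher number here means that more compound is needed for the effect, a lower number that less compound is needed:
- compound 1 `Cc1nn(-c2ncnc3nc[nH]c23)c2c1C(OC1CCCC1)CC(=O)N2`: 62 nM
- compound 2 `Cc1nn(-c2ncnc3nc[nH]c23)c2c1C(OCc1ccc(C(C)C)cc1)CC(=O)N2`: 1690 nM
- compound 3 `Cc1nn(-c2ncnc3nc[nH]c23)c2c1C(OCCn1nccc1C)CC(=O)N2`: 1620 nM

Compound 1 has the lowest number of the three in this assay. Both other compounds carry a larger group on the same oxygen and both sit far higher: a 27-fold higher number from compound 1 to compound 2 (1.44 log units; beyond the scatter) and a 26-fold higher number from compound 1 to compound 3 (1.42 log units; beyond the scatter). Between those two the change is a 1.0-fold lower number from compound 2 to compound 3 (0.02 log units; within the scatter), so the two larger replacements are indistinguishable on the numbers shown.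

Compound 4 `Cc1nn(-c2ncnc3nc[nH]c23)c2c1C(OCC(C)C)CC(=O)N2` has not been measured. It differs from compound 1 in one place: isobutyl in place of cyclopentyl on an oxygen on a saturated carbon. The two measured steps that bear on this change both describe an exchange of the cyclopentyl for something larger, and both were large increases. Here the incoming isobutyl is smaller than what leaves and keeps to a plain saturated chain with no ring, so the measured steps are only a loose guide; what a shorter, ring-free group does on this oxygen is not shown by any pair in hand. A modest rise in this assay is expected rather than a large one, since the large steps from compound 1 to compound 2 and compound 3 came with bulkier, ring-bearing groups. The expected step is a 2.6-fold higher number from compound 1 to compound 4 (0.41 log units; beyond the scatter). Compound 4 is estimated at 160 nM, with a range of 50 nM to 550 nM.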

Compound 4, half-maximal effective concentration: 111 nM
Compound 4: the middle estimate sits 1.4-fold (0.16 log units) above what was measured; low and high end bracket the measured number.
By their numbers in this assay, from the lowest: compounds 1 and 4 (each within the scatter of the next); then compounds 3 and 2 (each within the scatter of the next).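

In this assay, isobutyl in place of cyclopentyl on this oxygen gives a 1.8-fold higher number from compound 1 to compound 4 (0.25 log units; within the scatter) and so stays within the scatter, which shows that the closed carbon ring of compound 1 is not required for a number in this range. The isobutyl compound also stands well apart from the two larger groups, with a 15-fold lower number from compound 3 to compound 4 (1.16 log units; beyond the scatter) against the pyrazole-bearing chain and a 15-fold lower number from compound 2 to compound 4 (1.18 log units; beyond the scatter) against the 4-isopropylbenzyl group, so the large gap seen from compound 1 is now seen from a ring-free group as well. No measurement shown here explains these differences.

Both larger groups differ from isobutyl in size and in carrying an aromatic ring, so the compounds shown do not separate those two changes; a plain benzyl or a longer chain such as n-hexyl on the same oxygen would bear on this. Also open, as far as these compounds go, is how far the small end of this range extends, with groups such as methyl, ethyl or cyclopropyl, and whether an amine or a carboxylic acid at the end of the isobutyl chain is compatible with these numbers.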